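The source may hold more compounds than are shown below. What is called first, only, known or untested is meant among the compounds shown, and "the series" means these compounds.

Measured compounds:
Compound 1 `Cc1nn(C)c2c1C(c1ccc(C(F)(F)F)cc1)C(C#N)=C(N)O2`, in a functional assay on NCI-H2122 cells (Homo sapiens) for inhibition, read by microscopy, with a stated time of 10 days (on this read-out lower numbers stand for stronger inhibition and higher numbers for weaker inhibition), compound 1 gives 2200 nM.
Compound 2 `Cc1nn(C)c2c1C(c1ccc(C#N)cc1)C(C#N)=C(N)O2`, in this assay compound 2 gives 5600 nM.

Compound 2 holds the higher of the two numbers; the change from trifluoromethyl to cyano gave a 2.5-fold higher number from compound 1 to compound 2 (0.41 log units; beyond the scatter). Compound 3 `Cc1nn(C)c2c1C(c1ccc(C(C)C)cc1)C(C#N)=C(N)O2` differs from compound 2 in one place: isopropyl in place of cyano on an aromatic carbon. For the measured compounds named here, no measured step covers this exact exchange, but the step from compound 1 to compound 2 shows that this position responds to the group placed there. Compound 3 is therefore expected to give a modestly lower number, a 2.2-fold lower number from compound 2 to compound 3 (0.35 log units; beyond the scatter), close to compound 1. The estimate for compound 3 is 2500 nM, within 900 nM to 7000 nM.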

Compound 3, half-maximal inhibitory concentration: 4000 nM
Compound 3: middle estimate off by 1.6-fold (0.20 log units), on the low side; low and high end bracket the measured number.
By their numbers in this assay, from the lowest: compounds 1, 3 and 2 (each within the scatter of the next, the first and the last beyond it).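

Replacing cyano with isopropyl, which has no hydrogen-bond acceptor, gives a 1.4-fold lower number from compound 2 to compound 3 (0.15 log units; within the scatter), and replacing trifluoromethyl with isopropyl gives a 1.8-fold higher number from compound 1 to compound 3 (0.26 log units; within the scatter), so both steps stay within the scatter. This position therefore accepts an all-carbon group without a clear change, and among these three compounds, only compound 1 and compound 2 stand clearly apart. No measurement here explains these numbers. From the compounds shown here alone, it remains open whether an amine, a carboxylic acid or a longer chain at this position would move the number further in either direction.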